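Swapping the Aryl on the Triazole: What to Expect

This account rests on a few compounds, and the source may have more. Where it says the series, first, only, none or still open, it means among the compounds named here.

Among the measured compounds shown here, compound 2 `Cc1ccc(Cl)cc1-n1nncc1CN1C(=O)C2(C(C#N)=C(N)Oc3c(N)cc4nc5ccccc5nc4c32)c2ccccc21` gives 17300 nM in a functional assay on HepG2 cells (Homo sapiens) for antiproliferative activity, read by MTT assay, with a stated time of 48 h (a higher number here means a weaker inhibitor, a lower number a stronger inhibitor), the higher of the two numbers known so far, and compound 1 `N#CC1=C(N)Oc2c(N)cc3nc4ccccc4nc3c2C12C(=O)N(Cc1cnnn1-c1cccc(C(F)(F)F)c1)c1ccccc12` at 15800 nM lies within the scatter of it. For the measured compounds named here, the only measured step, a 1.1-fold higher number from compound 1 to compound 2 (0.04 log units; within the scatter), exchanged one aryl group for another on the same aromatic nitrogen. Compound 3 `N#CC1=C(N)Oc2c(N)cc3nc4ccccc4nc3c2C12C(=O)N(Cc1cnnn1-c1ccc(Cl)cc1[N+](=O)[O-])c1ccccc12` repeats that kind of exchange: 4-chloro-2-nitrophenyl in place of 5-chloro-2-methylphenyl on an aromatic nitrogen. With a single comparable step to go on, and that one flat, no change beyond the scatter is expected, a 1.0-fold lower number from compound 2 to compound 3 (0.01 log units; within the scatter). Compound 3 is therefore estimated at 17000 nM, in a range from 8000 nM to 36000 nM.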

Compound 3, half-maximal inhibitory concentration: > 50000 nM
Compound 3: a limit, no number; the forecaster's own chance of this, stated with the estimate: 5%; at least 2.9-fold (0.46 log units) between middle value and limit.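

In this assay, the aryl group on this aromatic nitrogen proved able to move the number, which the earlier exchange had not shown: 4-chloro-2-nitrophenyl gave an at least 2.8-fold higher number from compound 2 to compound 3 (0.46 log units; beyond the scatter) and an at least 3.1-fold higher number from compound 1 to compound 3 (0.50 log units; beyond the scatter). Compound 3 carries a limit of the assay and not a number, so both steps give only a floor on the size of the change: the limit of > 50000 nM in this assay, at which 1 of the 3 values shown sits.

Left open is whether the nitro group or the place of the chlorine carries the step, and whether an amine in place of the nitro group would behave like the methyl group of compound 2.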